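The source may report more compounds than this note shows. Statements on the series, on what has been measured and on what is new or still open speak of the compounds shown alone.

Compound 1, `Cc1ccc(Cn2cc(CNC(=O)c3cnc(Nc4ccc(C#N)cc4)cc3Oc3c(C)cc(C)cc3C)nn2)cc1`: in an ADME assay on MT4 cells (Homo sapiens) for cytotoxicity, read by MTT assay, with a stated time of 5 days (on this read-out lower numbers stand for higher toxicity in this test and higher numbers for lower toxicity in this test), compound 1 gives 165000 nM.
Compound 2, `Cc1cc(C)c(Oc2cc(Nc3ccc(C#N)cc3)ncc2C(=O)NCc2cn(Cc3ccccc3C#N)nn2)c(C)c1`: compound 2 reaches only a limit of the test, > 219000 nM.
Compound 3, `Cc1cc(C)c(Oc2cc(Nc3ccc(C#N)cc3)ncc2C(=O)NCc2cn(Cc3ccc(F)cc3)nn2)c(C)c1`: compound 3 likewise reaches only a limit, >= 153000 nM.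

Compound 3 thus stands at a limit, as does compound 2, and its distance from compound 1 cannot be read: a step that the limit leaves unreadable from compound 1 to compound 3. Compound 4, `Cc1cc(C)c(Oc2cc(Nc3ccc(C#N)cc3)ncc2C(=O)NCc2cn(CC(=O)N3CCOCC3)nn2)c(C)c1`, differs from compound 3 by (morpholin-4-yl)carbonyl in place of 4-fluorophenyl on a saturated chain carbon bound to an aromatic nitrogen. The measured steps at the same place give little guidance: an at least 1.3-fold higher number from compound 1 to compound 2 (0.12 log units; that floor lies within the scatter) and a step that the two limits leave unreadable from compound 2 to compound 3. No step beyond the scatter has been seen among these three, so for compound 4 no step beyond the scatter is expected in this assay, a step that the limit leaves unreadable from compound 3 to compound 4. Compound 4 is estimated at 200000 nM, between 120000 nM and 300000 nM, most likely reported again only as a limit.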

Compound 4, half-maximal cytotoxic concentration: 181000 nM
Compound 4: middle estimate off by 1.1-fold (0.04 log units), on the high side, within the range that was stated.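

In this assay, a (morpholin-4-yl)carbonyl group brings the first non-aromatic ring to this place, yet the read-out shows no step beyond the scatter: a 1.1-fold higher number from compound 1 to compound 4 (0.04 log units; within the scatter). The comparison with the 2-cyanophenyl group gives only a floor, an at least 1.2-fold lower number from compound 2 to compound 4 (0.08 log units; that floor lies within the scatter). The step to compound 4 from the 4-fluorophenyl compound cannot be read, and the same holds for the other steps that involve compound 3, which stands at a limit: the limit of >= 153000 nM in this assay, at which 1 of the 4 values shown sits.

Still open, from the compounds shown here alone, is whether an amine, a carboxylic acid or a longer chain at this place would give a step beyond the scatter.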